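This account rests on a few compounds, and the source may have more. Where it says the series, first, only, none or still open, it means among the compounds named here.

Compounds measured so far in an ADME assay on HepG2 cells (Homo sapiens), read by MTT assay, with a stated time of 72 h, in the presence of a further agent that is not named here; on this read-out higher numbers stand for weaker inhibition and lower numbers for stronger inhibition

Compound 1 `O=C(Nc1ccccc1)Oc1ccc(Cl)cc1C(=O)Nc1ccc(F)cc1` gives 3250 nM
Compound 2 `O=C(NC1CCCCC1)Oc1ccc(Cl)cc1C(=O)Nc1ccc(F)cc1` gives 8600 nM
Compound 3 `O=C(NCc1ccccc1)Oc1ccc(Cl)cc1` gives > 125000 nM as a limit of the assay and not a number

Compound 1 holds the lower of the two true numbers. Cyclohexyl in place of phenyl on an amide-type nitrogen gives a 2.6-fold higher number from compound 1 to compound 2 (0.42 log units; beyond the scatter) and is the only measured step. Compound 4 `O=C(Nc1ccccc1)Oc1ccc(Cl)cc1C(=O)Nc1ccc(Cl)cc1` differs from compound 1 by chloro in place of fluoro on an aromatic carbon as chloro in place of fluoro on an aromatic carbon, para to a large group. The measured step lies elsewhere in the structure, and none changes this halogen, so it bears only loosely. In this assay no step beyond the scatter is expected, and no direction is favoured. The estimated change is a 1.1-fold lower number from compound 1 to compound 4 (0.03 log units; within the scatter) for this swap. For compound 4 the expected value is 3000 nM with 1300 nM to 7000 nM as the estimated range.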

Compound 4, half-maximal inhibitory concentration: 900 nM
Compound 4: the middle estimate sits 3.3-fold (0.52 log units) above what was measured; measured number outside the range, below it.
By their numbers in this assay, from the lowest: compound 4; then compound 1; then compound 2. At a limit, above all of these: compound 3.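

In this assay the halogen of the 4-chlorophenyl group turns out to count: chloro in place of fluoro on an aromatic carbon, para to a large group, gives a 3.6-fold lower number from compound 1 to compound 4 (0.56 log units; beyond the scatter). Within the data shown here, the only earlier step, a 2.6-fold higher number from compound 1 to compound 2 (0.42 log units; beyond the scatter), changed the group on the amide-type nitrogen and left this halogen untouched. Nothing measured here accounts for the lower number. The compounds shown leave open whether bromo or iodo at this place would continue the trend, and whether a methoxy group, an amine or a carboxylic acid there would keep it.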